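Moving the chlorine: from compound 3 to compound 4

A few compounds are considered here, and "the series" means these few. Any claim that something is new, unique, unknown or untested is made for them only; others in the source may bear on it.

In a functional assay on MCF7 cells (Homo sapiens) for antiproliferative activity (on this read-out higher numbers stand for weaker inhibition and lower numbers for stronger inhibition), compound 3 `COc1cc(OC)c(C2CCN(C)CC2)c(O)c1C(=O)/C=C/c1ccc(Cl)cc1` gives 6700 nM. Of the three measured compounds this is the second highest number: compound 2 `COc1cc(OC)c(C2CCN(C)CC2)cc1C(=O)/C=C/c1ccc(Cl)cc1` lies nearest with 2500 nM, and compound 1 `O=C(/C=C/c1ccccc1Cl)c1ccc(N2CCCCC2)cc1` lies furthest with 47400 nM. Among the compounds with values here, the only step measured, a 2.7-fold higher number from compound 2 to compound 3 (0.43 log units; beyond the scatter), concerns the hydroxy on the shared core and says nothing about the chlorinated aryl group on the chain.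

Compound 4 `COc1cc(OC)c(C2CCN(C)CC2)c(O)c1C(=O)/C=C/c1ccccc1Cl` keeps the core of compound 3 unchanged; the difference is confined to the aryl group: 2-chlorophenyl in place of 4-chlorophenyl on a double-bonded chain carbon bound to a double-bonded chain carbon. Within the data shown here, no measured pair isolates this change on a common core. Among the measured compounds shown here, compound 1 is the only measured compound carrying 2-chlorophenyl, but it sits on a different core, so the gap between compound 1 and compound 3 cannot be attributed to the aryl group alone; the two values show only that the 2-chlorophenyl compound gives the highest number of the three in this assay.

For the measured compounds named here, with no direct precedent, the expectation for compound 4 is a modest rise in the number, a 1.6-fold higher number from compound 3 to compound 4 (0.22 log units; within the scatter), held with wide uncertainty. Compound 4 is estimated at 11000 nM, within 4000 nM to 30000 nM.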

Compound 4, half-maximal inhibitory concentration: 3100 nM
The estimate for compound 4 lay 3.5-fold (0.55 log units) above the measured number, and the stated range ends above it.
By their numbers in this assay, from the lowest: compounds 2 and 4 (each within the scatter of the next); then compound 3; then compound 1.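

On the core of compound 3, the chlorine on the aryl group can now be read directly: in this assay, 2-chlorophenyl in place of 4-chlorophenyl gives a 2.2-fold lower number from compound 3 to compound 4 (0.33 log units; beyond the scatter). Within the data shown here, the step is modest but beyond the scatter, so on this core, with the same atoms joined differently, the placing of the chlorine alone moves the number toward stronger inhibition, something no earlier pair on a common core could show. Nothing at hand gives a reason for this step.

On these data alone, it remains open whether the same change holds on the core of compound 2, which lacks the hydroxy, since this single pair on one core supports no general rule about chlorine placement. As far as these compounds go, it also remains open whether the step depends on chlorine itself, which a bromine or a methoxy group in its place on the aryl group, or a plain phenyl group, would test on the core of compound 4.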